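The source may hold more compounds than are shown below. What is called first, only, known or untested is meant among the compounds shown, and "the series" means these compounds.

Measured compounds:
- Compound 1, `Cc1cc(Nc2cc(-c3ccccc3)[nH]n2)n2nc(SCc3c(Cl)cccc3Cl)nc2n1`: 5180 nM
- Compound 2, `Cc1cc(Nc2cc(-c3ccccc3)[nH]n2)n2nc(SCc3ccc(F)cc3)nc2n1`: 8110 nM
- Compound 3, `Cc1cc(Nc2cc(-c3ccccc3)[nH]n2)n2nc(SCc3ccc(C(F)(F)F)cc3)nc2n1`: 4240 nM

All three share one core and differ only in the aryl group on a saturated chain carbon bound to a sulfur. In a functional assay on PC-9 cells (Homo sapiens) for inhibition, read by MTT assay, with a stated time of 72 h (a lower number here means a stronger inhibitor, a higher number a weaker inhibitor), compound 3 gives the lowest of the three numbers, but it stands within the scatter of both others: a 1.2-fold lower number from compound 1 to compound 3 (0.09 log units; within the scatter) and a 1.9-fold lower number from compound 2 to compound 3 (0.28 log units; within the scatter), while a 1.6-fold higher number from compound 1 to compound 2 (0.19 log units; within the scatter) spans the whole set. Three quite different aryl groups thus leave this assay essentially unmoved.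

Compound 4, `Cc1cc(Nc2cc(-c3ccccc3)[nH]n2)n2nc(SCc3cccc4ccccc34)nc2n1`, is not yet measured. Its change from compound 3 is naphthalen-1-yl in place of 4-(trifluoromethyl)phenyl on a saturated chain carbon bound to a sulfur. Going by the values given here, the steps that bear on it are those that swap the aryl group at the same place, from compound 1 to compound 3 and from compound 2 to compound 3, both within the scatter. No shown step gives a reason to expect a move beyond the scatter here, so compound 4 is expected to sit near compound 3, with a 1.1-fold higher number from compound 3 to compound 4 (0.03 log units; within the scatter) as the estimated step. The estimate for compound 4 is 4500 nM, with a range from 2000 nM to 10000 nM.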

Compound 4, half-maximal inhibitory concentration: 3950 nM
Compound 4: middle estimate off by 1.1-fold (0.06 log units), on the high side; the range from low to high includes it.
By their numbers in this assay, from the lowest: compounds 4, 3, 1 and 2 (each within the scatter of the next, the first and the last beyond it).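

In this assay, naphthalen-1-yl has the same heavy-atom count as 4-(trifluoromethyl)phenyl but 2 six-membered aromatic rings of carbon only, and the exchange stays within the scatter (a 1.1-fold lower number from compound 3 to compound 4 (0.03 log units; within the scatter)), as does its exchange for 2,6-dichlorophenyl (a 1.3-fold lower number from compound 1 to compound 4 (0.12 log units; within the scatter)). Going by these compounds alone, only the exchange for 4-fluorophenyl passes the scatter, and only modestly (a 2.1-fold lower number from compound 2 to compound 4 (0.31 log units; beyond the scatter)); it is the first step at this place to do so, while compound 1 and compound 3 stay within the scatter of both ends of the set. No measurement shown accounts for this step.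

Going by these compounds, whether an aryl group bearing an amine or a carboxylic acid would move the number further remains open. So does the effect of a longer chain carrying the aryl group on the sulfur.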